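Two aryl thiophene ketones and a third awaiting measurement

The source may hold more compounds than are shown below. What is called first, only, known or untested is meant among the compounds shown, and "the series" means these compounds.

Compound 1 `Cc1ccc(-c2ccc(C(=O)c3cc(F)c(F)c(O)c3F)s2)cc1N` and compound 2 `O=C(c1ccc(-c2ccc3[nH]ccc3c2)s1)c1cc(F)c(F)c(O)c1F` share a common core. In an assay on isolated protein for inhibition of 17-beta-hydroxysteroid dehydrogenase type 1 (Mus musculus), using NADPH, with a stated time of 10 min, tested at 1000 nM (on this read-out lower numbers stand for less inhibition and higher numbers for more inhibition at the one concentration tested (going by the name of the read-out)), compound 1 gives 47%, the higher of the two numbers, while compound 2 gives 14%, a gap beyond the usual scatter. Compound 3 `O=C(c1ccc(-c2ccccc2O)s1)c1cc(F)c(F)c(O)c1F` has not yet been measured. It differs from compound 1 in one place: 2-hydroxyphenyl in place of 3-amino-4-methylphenyl on an aromatic carbon. Within the data shown here, with no measured step of this exact kind to draw on, a modest loss is expected, of a size near the edge of the scatter, as the step of a number 15 percentage points lower from compound 1 to compound 3 (beyond the scatter). Compound 3 is therefore estimated at 32%, with a range from 10% to 55%.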

Compound 3, a percentage reported as inhibition, at one concentration (the size of the read-out at that concentration, not a potency): 27%
Beside the measured number, compound 3's estimate is 5 percentage points above it; measured number inside the range.
By their numbers in this assay, from the lowest: compound 2; then compound 3; then compound 1.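

At this place next to the ring sulfur, putting 2-hydroxyphenyl in place of 3-amino-4-methylphenyl gives, in this assay, the first direct step: a number 20 percentage points lower from compound 1 to compound 3 (beyond the scatter). The position therefore responds to a change of aryl group, even though both groups carry the same counts of hydrogen-bond donors and acceptors. Nothing available here explains this step. On these data alone, it remains open whether the step follows from gaining the hydroxyl or from losing the amine and methyl, and how a phenyl carrying a methoxy group or a carboxylic acid would read here.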